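Shortening the Phenylalkyl Chain on a Crown Ether Ester

The compounds below may be only part of what the source reports. "The series", "measured", "known", "first", "only" and "open" are said of these compounds alone.

Among the compounds with values here, compound 1 `O=C(CCCCCc1ccccc1)OCC1COCCOCCOCCOCCOCCO1` is the only compound here with a fully numbered result: in a functional assay on SW1573 cells (Homo sapiens) for inhibition, read by sulforhodamine B assay, with a stated time of 48 h (a lower number here means a stronger inhibitor of growth, a higher number a weaker inhibitor of growth), compound 1 gives 78000 nM. Compound 2 `CC/C=C/CC(=O)OCC1COCCOCCOCCOCCOCCO1` reaches only a limit of the assay, > 100000 nM. Compound 3 `O=C(CCCCC1CCCCC1)OCC1COCCOCCOCCO1` likewise stops at a limit, > 100000 nM. Within the data shown here, the one measured step, an at least 1.2-fold higher number from compound 1 to compound 2 (0.10 log units; that floor lies within the scatter), is capped by the limit of > 100000 nM in this assay, at which 2 of the 3 values shown sit, and says nothing beyond the scatter. Compound 4 `O=C(CCCCc1ccccc1)OCC1COCCOCCOCCOCCOCCO1` differs from compound 1 by phenyl in place of benzyl on a saturated chain carbon, four bonds along the chain from a carbonyl carbon. Among the measured compounds shown here, no measured step tracks that change directly, and the step to compound 2 is only a floor; for compound 4 no movement beyond the scatter is expected, so the estimated step is a 1.2-fold higher number from compound 1 to compound 4 (0.06 log units; within the scatter). Compound 4 is therefore expected to give 90000 nM, between 45000 nM and 180000 nM.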

Compound 4, concentration for 50% growth inhibition: > 100000 nM
Compound 4: only a limit was reported (the forecaster's own chance of this, stated with the estimate: 40%); middle value at least 1.1-fold (0.04 log units) away from the limit.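

Phenyl in place of benzyl on a saturated chain carbon, four bonds along the chain from a carbonyl carbon, gives an at least 1.2-fold higher number from compound 1 to compound 4 (0.10 log units; that floor lies within the scatter) in this assay. Compound 4 gives > 100000 nM, which is a limit of the assay and not a number. The step between compound 2 and compound 4 cannot be read, and the shorter chain adds one more compound to those stopping at the same point: the limit of > 100000 nM in this assay, at which 3 of the 4 values shown sit.

Still open, going by these compounds, is whether a longer chain than that of compound 1, or an amine on the phenyl ring, would give a number clearly lower than compound 1's.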